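The source may report more compounds than this note shows. Statements on the series, on what has been measured and on what is new or still open speak of the compounds shown alone.

Working notes on the series built on the shared core of compound 2 `Oc1nc2nonc2nc1Nc1ccccc1`. In an assay on mitochondria from L6 cells (Rattus norvegicus) for activation, with a stated time of 90 min (a higher number here means that more compound is needed for the effect, a lower number that less compound is needed), compound 2 gives 66700 nM. Compound 1 `Oc1nc2nonc2nc1Nc1ccccc1F` carries fluoro in place of hydrogen on an aromatic carbon, and in this assay compound 1 gives 12500 nM, a step of a 5.3-fold lower number from compound 2 to compound 1 (0.73 log units; beyond the scatter). Compound 3 `Oc1nc2nonc2nc1Nc1ccc(C(F)(F)F)cc1` differs from compound 2 by trifluoromethyl in place of hydrogen on an aromatic carbon; in this assay compound 3 gives 10400 nM, a step of a 6.4-fold lower number from compound 2 to compound 3 (0.81 log units; beyond the scatter). The values of compound 1 and compound 3 lie within the scatter of each other.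

Compound 4 `Oc1nc2nonc2nc1Nc1ccc(C(F)(F)F)cc1F` is not yet measured. It differs from compound 3 by fluoro in place of hydrogen on an aromatic carbon. This is the same kind of change as that from compound 2 to compound 1, but here the place is, in addition, meta to a trifluoromethyl group, so the step need not match. Among the measured compounds shown here, a step of a 3.5-fold lower number from compound 3 to compound 4 (0.54 log units; beyond the scatter) is expected, resting on a 5.3-fold lower number from compound 2 to compound 1 (0.73 log units; beyond the scatter) and tempered since only one pair shows that step. Compound 4 is therefore estimated at 3000 nM, within 1000 nM to 12000 nM.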

Compound 4, half-maximal effective concentration: 2600 nM
For compound 4 the middle estimate is 1.2-fold (0.06 log units) above the measured one; measured number inside the range.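

In this assay fluoro in place of hydrogen on an aromatic carbon gives a 4.0-fold lower number from compound 3 to compound 4 (0.60 log units; beyond the scatter) and the step carries over from the core of compound 2 to the core of compound 3: the same change on two cores in this assay, a 5.3-fold lower number (0.73 log units; beyond the scatter) from compound 2 to compound 1 and a 4.0-fold lower number (0.60 log units; beyond the scatter) from compound 3 to compound 4, 1.3-fold (0.13 log units) apart, within the scatter of two such steps. The entry of a trifluoromethyl group where a hydrogen stood gives a 4.8-fold lower number from compound 1 to compound 4 (0.68 log units; beyond the scatter) and this step carries over as well: the same change on two cores in this assay, a 6.4-fold lower number (0.81 log units; beyond the scatter) from compound 2 to compound 3 and a 4.8-fold lower number (0.68 log units; beyond the scatter) from compound 1 to compound 4, 1.3-fold (0.13 log units) apart, within the scatter of two such steps. These four compounds thus show the two changes acting independently of each other, but they form a single square and do not show that either step would hold on any other core or at any other place.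

Open, as far as these compounds go, is whether an amine, a carboxylic acid or a methoxy group on the same ring would give steps of like size. Also open, from the compounds shown here alone, is whether the hydroxy group on the shared core can be replaced.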